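Amide substituent change: benzyl replacing trifluoromethylphenyl

The source may report more compounds than this note shows. Statements on the series, on what has been measured and on what is new or still open speak of the compounds shown alone.

Among the measured compounds shown here, compound 2 `COc1cc(-c2cc(C(=O)O)c3ccccc3n2)ccc1OCC(=O)Nc1ccccc1C(F)(F)F` carries the lowest of the two numbers measured so far in an ADME assay on HaCaT cells (Homo sapiens) for inhibition; a higher number here means a weaker inhibitor, a lower number a stronger inhibitor; in this assay compound 2 gives 102000 nM. For the measured compounds named here, its only neighbour is compound 1 `COc1cc(-c2cc(C(=O)O)c3ccccc3n2)ccc1OCC(=O)Nc1ccccc1Cl`, which in this assay gives 210000 nM; the step of a 2.1-fold lower number from compound 1 to compound 2 (0.31 log units; beyond the scatter) describes the swap of trifluoromethyl for chloro on the aromatic carbon. Compound 3 `COc1cc(-c2cc(C(=O)O)c3ccccc3n2)ccc1OCC(=O)NCc1ccccc1` differs from compound 2 as follows: benzyl in place of 2-(trifluoromethyl)phenyl on an amide-type nitrogen. Going by the values given here, no measured step covers this change; the step from compound 1 to compound 2 concerns only the substituent on the aryl ring that now leaves, so it offers no direct guide. Both measured values sit in a narrow band, and the change is expected to move the number little, if at all, beyond the scatter, with a step of a 1.7-fold higher number from compound 2 to compound 3 (0.22 log units; within the scatter) expected from compound 2 to compound 3. For compound 3 the estimate in this assay is 170000 nM, with a range of 70000 nM to 400000 nM.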

Compound 3, half-maximal inhibitory concentration: > 300000 nM
Compound 3: a limit, no number; the forecaster's own chance of this, stated with the estimate: 15%; middle value at least 1.7-fold (0.24 log units) from the limit.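

Compound 3 stands at a limit and not at a number in this assay: the limit of > 300000 nM in this assay, at which 1 of the 3 values shown sits.

Benzyl in place of 2-(trifluoromethyl)phenyl on the amide-type nitrogen gives an at least 2.9-fold higher number from compound 2 to compound 3 (0.46 log units; beyond the scatter), so replacing the whole aryl group moves the read-out upward, which the earlier swap of a single substituent on that ring could not show. Benzyl in place of 2-chlorophenyl gives an at least 1.4-fold higher number from compound 1 to compound 3 (0.15 log units; that floor lies within the scatter), and with that floor inside the scatter this pair fixes no order on its own.

Going by these compounds, the full size of both steps stays unknown, since the value of compound 3 can be read only as a limit. Also open, on these data alone, is how the read-out would respond to a longer chain such as 2-phenylethyl, or to an amine, in place of benzyl on the amide-type nitrogen.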